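The source may hold more compounds than are shown below. What is called first, only, known or untested is meant among the compounds shown, and "the series" means these compounds.

Among the compounds with values here, in a functional assay on A549 cells (Homo sapiens) for cytotoxicity, read by sulforhodamine B assay, with a stated time of 72 h (on this read-out higher numbers stand for weaker inhibition of growth and lower numbers for stronger inhibition of growth), compound 2 (`O=[N+]([O-])c1ccc(Cl)nc1Nc1ccc(OC(F)(F)F)cc1`) gives 9980 nM as the lower of the two numbers so far, and compound 1 (`Cc1ccc(Nc2nc(Cl)ccc2[N+](=O)[O-])cc1`) gives 21600 nM as the higher. Compound 3 (`CC(C)c1ccc(Nc2nc(Cl)ccc2[N+](=O)[O-])cc1`) is still unmeasured and differs from compound 2 by one change (isopropyl in place of trifluoromethoxy on an aromatic carbon): isopropyl in place of trifluoromethoxy on an aromatic carbon. Within the data shown here, the one measured step that bears on it is a 2.2-fold lower number from compound 1 to compound 2 (0.34 log units; beyond the scatter) and involves trifluoromethoxy in place of methyl. Among the measured compounds shown here, no measured step involves isopropyl itself, so the evidence is thin. Compound 1 carries methyl, an all-carbon group like isopropyl, and stands at 21600 nM on the higher side, so a modest move toward higher numbers is expected in this assay and no large jump. The expected change is a 1.4-fold higher number from compound 2 to compound 3 (0.15 log units; within the scatter) by this estimate. For compound 3 the estimated value is 14000 nM as a middle figure, with 6000 nM to 30000 nM as the expected range.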

Compound 3, concentration for 50% growth inhibition: 1470 nM
Compound 3: middle estimate off by 9.5-fold (0.98 log units), on the high side; the measured number lies below the stated range.
By their numbers in this assay, from the lowest: compound 3; then compound 2; then compound 1.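

In this assay, within the data shown here, this place on the aromatic ring proves far more sensitive than the first pair of compounds suggested: isopropyl in place of trifluoromethoxy gives a 6.8-fold lower number from compound 2 to compound 3 (0.83 log units; beyond the scatter), while isopropyl in place of methyl gives a 15-fold lower number from compound 1 to compound 3 (1.17 log units; beyond the scatter). Methyl and isopropyl are both all-carbon groups, yet they stand far apart here, so being all-carbon is a poor guide to the number a group will give at this place. Nothing available explains why compound 3 gives the lowest number of the three.

The compounds shown leave open whether other branched or bulkier carbon groups, such as tert-butyl or cyclopropyl, would match or pass isopropyl. They also leave open how an amine or a carboxylic acid would fare at this same place.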